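Thiourea aryl swap on a weak benzamide series

The source may hold more compounds than are shown below. What is called first, only, known or untested is meant among the compounds shown, and "the series" means these compounds.

The shared core carries an amide, a benzamide and a thiourea on an aryl ring; three compounds have numbers in a functional assay on HeLa cells (Homo sapiens) for antiproliferative activity, with a stated time of 24 h; on this read-out lower numbers stand for stronger inhibition and higher numbers for weaker inhibition. Compound 1 `NC(=O)c1c(NC(=O)c2ccccc2F)sc2c1CCN(C(=S)Nc1ccccc1Cl)C2` gives 19400 nM. Compound 3 `Cc1ccccc1C(=O)Nc1sc2c(c1C(N)=O)CCN(C(=S)Nc1ccccc1Cl)C2` gives 35300 nM. For compound 2 `NC(=O)c1c(NC(=O)c2ccccc2I)sc2c1CCN(C(=S)Nc1ccccc1Cl)C2` only a limit of the assay is known, > 50000 nM, so compound 2 stands at the weak end of the numbers shown, as the limit of > 50000 nM in this assay, at which 1 of the 3 values shown sits, states. The steps measured so far all sit on the benzamide ring: an at least 2.5-fold higher number from compound 1 to compound 2 (0.41 log units; beyond the scatter), a 1.8-fold higher number from compound 1 to compound 3 (0.26 log units; within the scatter) and an at least 1.4-fold lower number from compound 2 to compound 3 (0.15 log units; that floor lies within the scatter).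

Compound 4 `NC(=O)c1c(NC(=O)c2ccccc2I)sc2c1CCN(C(=S)Nc1ccccc1C(F)(F)F)C2` differs from compound 2 elsewhere, on the thiourea aryl: trifluoromethyl in place of chloro on an aromatic carbon. Among the measured compounds shown here, no measured step touches this ring, so the expectation rests only on where compound 2 itself stands and on the whole series sitting at weak numbers. The expected step that the limit leaves unreadable from compound 2 to compound 4 is therefore set near nothing beyond the scatter. Compound 4 is estimated at 60000 nM, in a range from 20000 nM to 200000 nM, with a fair chance that this assay again returns only a limit rather than a number.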

Compound 4, half-maximal inhibitory concentration: 49200 nM
Beside the measured number, compound 4's estimate is 1.2-fold (0.09 log units) above it; the measured number falls inside the stated range.
By their numbers in this assay, from the lowest: compounds 1, 3 and 4 (each within the scatter of the next, the first and the last beyond it). At a limit, above all of these: compound 2.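

The thiourea aryl, which none of the earlier steps touched, now has its first reading in this assay, and the swap of chloro for trifluoromethyl gives an at least 1.0-fold lower number from compound 2 to compound 4 (0.00 log units; that floor lies within the scatter) with no change beyond the scatter shown. Among the compounds shown here, this floor fixes neither the size nor the direction of the change, so the data do not show whether trifluoromethyl and chloro differ on this ring when the benzamide ring carries iodo; what is new is only that compound 4 returns a number where compound 2 does not. The value for compound 2 remains a limit and not a number, which leaves the upper end of this step unknown: the limit of > 50000 nM in this assay, at which 1 of the 4 values shown sits.

A real size for this change would need a number for compound 2, or the same swap made on the fluoro benzamide of compound 1, whose value can be read. Also open, on these data alone, is whether a different group on this aromatic carbon, such as methoxy, an amine or a carboxylic acid, would move the number beyond the scatter.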